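The source may report more compounds than this note shows. Statements on the series, on what has been measured and on what is new or still open speak of the compounds shown alone.

Measured in a toxicity assay on KB cells (Homo sapiens) for cytotoxicity, read by fluorescence, with a stated time of 3 days; a lower number here means that less compound is needed, a higher number that more compound is needed for the effect:
- Compound 1 `CCCCOC(=O)CNC(=O)[C@H](CSc1ccc([N+](=O)[O-])cc1[N+](=O)[O-])NC(=O)CC[C@H](NC(=O)CC(C)C)C(=O)OCCCC`: 59.6 uM
- Compound 2 `CCCCOC(=O)CNC(=O)[C@H](CSc1ccc([N+](=O)[O-])cc1[N+](=O)[O-])NC(=O)CC[C@H](NC(=O)c1ccccc1)C(=O)OCCCC`: > 300 uM, a limit of the assay

Compound 2 stands at the limit of > 300 uM in this assay, at which 1 of the 2 values shown sits, so no exact number is known for it. Compound 3 `CCCCOC(=O)CNC(=O)[C@H](CSc1ccc([N+](=O)[O-])cc1[N+](=O)[O-])NC(=O)CC[C@H](NC(=O)OC)C(=O)OCCCC`, not yet measured, differs from compound 2 in one group: methoxy in place of phenyl on a carbonyl carbon. Among the measured compounds shown here, the only measured step bearing on this is an at least 5.0-fold higher number from compound 1 to compound 2 (0.70 log units; beyond the scatter), for phenyl in place of isobutyl on a carbonyl carbon, so with the phenyl gone a lower number is expected in this assay, closer to compound 1 at 59.6 uM. The estimated step is an at least 2.7-fold lower number from compound 2 to compound 3 (0.43 log units; beyond the scatter). For compound 3 the estimated value is 110 uM, with an expected range from 35 uM to 300 uM.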

Compound 3, concentration for half-maximal effect: > 300 uM
Compound 3: only a limit was reported; the forecaster's own chance of this, stated with the estimate: 30%; at least 2.7-fold (0.43 log units) between middle value and limit.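

On this carbonyl carbon, methoxy in place of isobutyl gives an at least 5.0-fold higher number from compound 1 to compound 3 (0.70 log units; beyond the scatter). A group with no ring therefore raises the number in this assay just as phenyl did, so the aromatic ring is not needed for that rise. The step between compound 2 and compound 3 cannot be read because both stand at the same limit: the limit of > 300 uM in this assay, at which 2 of the 3 values shown sit.

From the compounds shown here alone, how far past that limit either compound lies remains unknown, so phenyl and methoxy cannot be ranked. Also open, going by these compounds, is whether a longer chain such as hexyl, or an amine, on this carbonyl carbon would give a number nearer to that of compound 1.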